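The compounds below may be only part of what the source reports. "The series", "measured", "known", "first", "only" and "open" are said of these compounds alone.

Working notes on the series. Compound 1 `COc1ccc(-c2nnc(N3CCN(C(=O)CN4CCN(c5ccccc5OC)CC4)CC3)nc2-c2ccc(OC)cc2)cc1` and compound 2 `COc1ccc(-c2nnc(N3CCN(C(=O)CN4CCN(c5ccccc5Cl)CC4)CC3)nc2-c2ccc(OC)cc2)cc1` share one core; compound 3 `COc1cccc(N2CCN(CC(=O)N3CCN(c4nnc(-c5ccc(Cl)cc5)c(-c5ccc(Cl)cc5)n4)CC3)CC2)c1` and the as yet unmeasured compound 4 `O=C(CN1CCN(c2cccc(Cl)c2)CC1)N1CCN(c2nnc(-c3ccc(Cl)cc3)c(-c3ccc(Cl)cc3)n2)CC1` share another, and the difference between the two cores is not broken down here. All three measured compounds were read in a functional assay on MCF7 cells (Homo sapiens) for cytotoxicity, read by MTT assay, with a stated time of 24 h; on this read-out higher numbers stand for weaker inhibition and lower numbers for stronger inhibition.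

Compound 1 returns only a limit in this assay, > 821000 nM. Compound 2 also returns only a limit, > 814000 nM. The change from compound 1 to compound 2 is chloro in place of methoxy on an aromatic carbon, and the step that the two limits leave unreadable from compound 1 to compound 2 cannot be sized because the limit of > 821000 nM in this assay, at which 1 of the 3 values shown sits, and the limit of > 814000 nM in this assay, at which 1 of the 3 values shown sits, are both limits rather than numbers.

Compound 3 is the only one of the three to give a number in this assay, 149000 nM. The change from compound 3 to compound 4 is chloro in place of methoxy on an aromatic carbon. It is the same kind of change as that from compound 1 to compound 2, not the same: there the group sits ortho to a large group, here meta to a large group. The measured pair therefore offers no readable size for this kind of change, and no direction either.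

With nothing to push the value one way or the other, the expected step is a 1.0-fold higher number from compound 3 to compound 4 (0.00 log units; within the scatter), resting on compound 3 giving 149000 nM as the only anchor. Compound 4 is estimated at 150000 nM, with a likely range of 60000 nM to 400000 nM.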

Compound 4, half-maximal inhibitory concentration: > 803000 nM
Compound 4 gave a limit, no number; the forecaster's own chance of this, stated with the estimate: 20%; middle value at least 5.3-fold (0.72 log units) away from the limit.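

In this assay the new step is an at least 5.3-fold higher number from compound 3 to compound 4 (0.73 log units; beyond the scatter), so on the core of compound 3, 3-chlorophenyl in place of 3-methoxyphenyl, with the group meta to a large group, goes with weaker inhibition. Compound 4 gives a limit and not a number, > 803000 nM. The step from compound 1 to compound 2 on the other core cannot be read, and the change there also sits at another place on the ring, so the measured pairs show a direction on one core only and do not show that the change carries from one core to the other.

Open, from the compounds shown here alone, is how an amine or a carboxylic acid would read in this assay at the same place on the phenyl ring of compound 3, where only methoxy and chloro stand so far. Also open, going by these compounds, is what a change of core alone does to the read-out, and whether 3-chlorophenyl and 3-methoxyphenyl on the core of compound 1 would stand apart as they do on the core of compound 3.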